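A few compounds are considered here, and "the series" means these few. Any claim that something is new, unique, unknown or untested is made for them only; others in the source may bear on it.

Compound 1 `COc1cccc(CNCCCNc2ccnc3cc(-c4ccc(C(C)(C)C)cc4)ccc23)c1O` gives 32000 nM in a physicochemical assay for solubility, with a stated time of 18 h, at pH 7.4; a lower number here means a less soluble compound, a higher number a more soluble compound. Compound 2 `COc1ccc(Oc2ccc3c(NCCCNCc4cccc(OC)c4O)ccnc3c2)cc1` gives 14500 nM in this assay.

Among the measured compounds shown here, compound 2 stands lowest of the two numbers; the only measured step is a 2.2-fold lower number from compound 1 to compound 2 (0.34 log units; beyond the scatter). Compound 3 `COc1cccc(CNCCCNc2ccnc3cc(-c4ccc(C(F)(F)F)cc4)ccc23)c1O` is not yet measured; the change is 4-(trifluoromethyl)phenyl in place of 4-methoxyphenoxy on an aromatic carbon. That single step bears on it directly, being the reverse exchange at the same place, with a different group carried on the entering ring. A modest step upward, roughly undoing the earlier one, is therefore expected, and a 1.9-fold higher number from compound 2 to compound 3 (0.29 log units; within the scatter) is the estimated step. For compound 3 the expected value in this assay is 28000 nM, with a range from 10000 nM to 70000 nM.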

Compound 3, solubility: 32000 nM
Estimate against measurement, compound 3: 1.1-fold (0.06 log units) below; measured number inside the range.
By their numbers in this assay, from the lowest: compound 2; then compounds 1 and 3 (each within the scatter of the next).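

Among the compounds shown here, exchanging 4-methoxyphenoxy for 4-(trifluoromethyl)phenyl at this aromatic carbon gives a 2.2-fold higher number from compound 2 to compound 3 (0.34 log units; beyond the scatter) in this assay and shows that a second phenyl-bearing compound also stands apart from the only 4-methoxyphenoxy compound. Trifluoromethyl in place of tert-butyl on the phenyl ring gives no change at the digits printed from compound 1 to compound 3 (within the scatter) and so separates these two groups by nothing in this read-out. The data available offer no explanation for either result.

On these data alone, whether the difference in compound 2 follows the linking oxygen or the methoxy group remains open. So does the outcome with an amine or a carboxylic acid on the phenyl ring.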